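The source may hold more compounds than are shown below. What is called first, only, known or untested is meant among the compounds shown, and "the series" means these compounds.

Measured compounds:
compound 1, `COc1ccc(-c2ncnc3c2ncn3C[C@@H]2C[C@H](CO)c3ccccc32)cc1`, 17600 nM
compound 2, `Cc1ccc(-c2ncnc3c2ncn3C[C@@H]2C[C@H](CO)c3ccccc32)cc1`, 15400 nM
compound 3, `Cc1ccc(C(=O)/C=C/c2cc(O)nc(O)n2)cc1`, 182000 nM

All three were tested in an ADME assay on L1210/0 cells (Mus musculus) for cytotoxicity, with a stated time of 48 h; on this read-out higher numbers stand for weaker inhibition and lower numbers for stronger inhibition. Compounds 1 and 2 share one core. In this assay compound 1 gives 17600 nM, and compound 2 gives 15400 nM. The two differ in a single place: methoxy in place of methyl on an aromatic carbon. The step is a 1.1-fold higher number from compound 2 to compound 1 (0.06 log units; within the scatter), so the two numbers cannot be told apart. Compound 3 is built on another core, and the difference between the two cores is not broken down here. In this assay compound 3 gives 182000 nM, the highest of the three numbers, and both compounds 1 and 2 stand beyond the scatter from it, so compound 3 is the weakest inhibitor among those measured.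

Compound 4, `COc1ccc(C(=O)/C=C/c2cc(O)nc(O)n2)cc1`, has not yet been measured in this assay. It arises from compound 3 by the same change that turns compound 2 into compound 1: methoxy in place of methyl on an aromatic carbon. The place is described in the same words in both cases, so it is the same change. Because the earlier step was a 1.1-fold higher number from compound 2 to compound 1 (0.06 log units; within the scatter), a similarly small step is expected here, estimated as a 1.0-fold higher number from compound 3 to compound 4 (0.02 log units; within the scatter). That expectation rests on a single precedent made on a different core, so it is held loosely. Compound 4 is estimated to give about 190000 nM, within a range from 90000 nM to 400000 nM.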

Compound 4, half-maximal inhibitory concentration: > 200000 nM
Compound 4: a limit, no number; the forecaster's own chance of this, stated with the estimate: 15%; middle value at least 1.0-fold (0.02 log units) away from the limit.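

In this assay compound 4 gives > 200000 nM, which is a limit of the assay and not a number. From the compounds shown here alone, the change from methyl to methoxy on the core of compound 3 can therefore be read only as a floor, an at least 1.0-fold higher number from compound 3 to compound 4 (0.04 log units; that floor lies within the scatter), and how large the real step is stays unknown; this floor does not conflict with the step on the other core, a 1.1-fold higher number from compound 2 to compound 1 (0.06 log units; within the scatter), but it does not show that the change acts alike on both cores. Set side by side, the two steps can be said neither to match nor to differ: the same change on two cores in this assay, a 1.1-fold higher number (0.06 log units; within the scatter) from compound 2 to compound 1 and an at least 1.0-fold higher number (0.04 log units; that floor lies within the scatter) from compound 3 to compound 4; the limit leaves it open whether they differ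

The compounds shown carry only methyl or methoxy on this aromatic carbon, para to a large group, so how an amine, a carboxylic acid or a longer chain would behave there on either core remains open. Going by these compounds, with a single pair on each core, and one of those pairs ending in a limit, it also remains open whether any one-place change keeps its size from one core to the other.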